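This account rests on a few compounds, and the source may have more. Where it says the series, first, only, none or still open, it means among the compounds named here.

Within the data shown here, compound 3 `CC(C)(C)c1cc(NC(=O)Nc2ccc(F)c(F)c2)n(-c2ccccc2)n1` sits at the lowest number of the three compounds measured so far in an assay on isolated protein for inhibition of STE20-like serine/threonine-protein kinase (Homo sapiens), read by thermal shift assay, tested at 10 uM (a higher number here means that the compound stabilises the target more against heat, a lower number that the compound stabilises the target less), where compound 3 gives 5.5 degrees C. Compound 1 `Cc1ccccc1NC(=O)Nc1cc(C(C)(C)C)nn1-c1ccccc1` gives 7.1 degrees C, and the step of a number 1.6 degrees C lower from compound 1 to compound 3 (beyond the scatter) lies beyond the scatter. Compound 2 `Cc1ccc(F)cc1NC(=O)Nc1cc(C(C)(C)C)nn1-c1ccccc1` gives 6 degrees C, and the step of a number 0.50 degrees C lower from compound 2 to compound 3 (within the scatter) stays within the scatter, so compound 3 is lower than compound 1 but cannot be set apart from compound 2.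

Compound 4 `CC(C)(C)c1cc(NC(=O)Nc2ccccc2)n(-c2ccccc2)n1` differs from compound 3 in one place: phenyl in place of 3,4-difluorophenyl on an amide-type nitrogen. Among the measured compounds shown here, two measured steps bear on this change. The step of a number 1.1 degrees C lower from compound 1 to compound 2 (beyond the scatter) shows a fluoro added to an aromatic carbon lowering the melting shift modestly, and the step of a number 1.6 degrees C lower from compound 1 to compound 3 (beyond the scatter) shows the move to a 3,4-difluorophenyl group lowering it a little more. Taking both fluorines away to reach a plain phenyl should therefore run the other way, by a modest amount just beyond the scatter. Compound 4 is expected to give 6.5 degrees C, with a likely range from 5 degrees C to 8 degrees C. The expected step is a number 1.0 degrees C higher from compound 3 to compound 4 (within the scatter).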

Compound 4, shift of the target's melting temperature: 7.7 degrees C
Estimate against measurement, compound 4: 1.2 degrees C below; measured number inside the range.
By their numbers in this assay, from the lowest: compounds 3 and 2 (each within the scatter of the next); then compounds 1 and 4 (each within the scatter of the next).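

In this assay, phenyl in place of 3,4-difluorophenyl on the amide-type nitrogen gives a clear gain (a number 2.2 degrees C higher from compound 3 to compound 4 (beyond the scatter)), and phenyl in place of 5-fluoro-2-methylphenyl gives a similar one (a number 1.7 degrees C higher from compound 2 to compound 4 (beyond the scatter)). The methyl group of compound 1, by contrast, can be replaced by hydrogen with no change that stands out from the scatter (a number 0.60 degrees C higher from compound 1 to compound 4 (within the scatter)), so compound 4 and compound 1 cannot be set apart. Among these four compounds, the two carrying fluoro substituents give the lower numbers, with no exception, but nothing shown explains this pattern.

Going by these compounds, it remains open whether a single fluoro on the plain phenyl would be enough to lower the number. Nor do these compounds show how a chloro, methoxy or amino group would behave on that ring.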